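The source may report more compounds than this note shows. Statements on the series, on what has been measured and on what is new or still open speak of the compounds shown alone.

Measured compounds:
- compound 1 `COc1cc(-c2cnn3cc(OC)c(C(C)C)nc23)ccn1`: 14%
- compound 2 `COc1cn2ncc(-c3ccnc(OC(C)C)c3)c2nc1-c1cnn(C)c1`: 50%

In an ADME assay on microsomes from liver (Rattus norvegicus) for metabolic stability, with a stated time of 60 min, tested at 1 uM (a higher number here means that more of the compound is left, a lower number that less of the compound is left), compound 1 at 14% is the lower of the two measured compounds, and the gap up to compound 2 is beyond the scatter. Compound 3 `COc1cnc2c(-c3ccnc(OC)c3)cnn2c1` differs from compound 1 by a single change, hydrogen in place of isopropyl on an aromatic carbon and nothing else. Among the compounds with values here, no measured pair shows this change alone, so its size remains uncertain. A moderate rise beyond the scatter is expected in this assay for this change. The estimated move is a number 31 percentage points higher from compound 1 to compound 3 (beyond the scatter) on this read-out. For compound 3 the expected value is 45% within an estimated range of 20% to 75% on the same measure.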

Compound 3, percent of the compound remaining: 10%
Compound 3: the middle estimate sits 35 percentage points above what was measured, outside the stated range (below it).
By their numbers in this assay, from the lowest: compounds 3 and 1 (each within the scatter of the next); then compound 2.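

In this assay, within the data shown here, hydrogen in place of isopropyl on this aromatic carbon gives a number 4 percentage points lower from compound 1 to compound 3 (within the scatter), the first step here that changes one place alone. Taking the isopropyl away from this position therefore does not lift the number, and the two compounds stand level on this read-out. Nothing on hand explains this result.

From the compounds shown here alone, whether another group on this carbon, such as an amine or a cyclopropyl ring, would move the number remains open. Going by these compounds, compound 2 differs from compound 1 in more than one place, so the source of its higher number also remains open.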